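Methoxybenzyl extension on the shared core: expected cytotoxicity

A few compounds are considered here, and "the series" means these few. Any claim that something is new, unique, unknown or untested is made for them only; others in the source may bear on it.

Measured compounds:
- compound 2 `CN1CCN(c2ccc(NC(=N)c3cc4cn[nH]c4cn3)cc2)CC1`: 45400 nM
- compound 3 `CN1CCN(c2ccc(NC(=N)c3cc4cnn(C)c4cn3)cc2)CC1`: 32300 nM
- compound 1 `COc1ccc(Cn2nc(-c3ccccc3)c3cc(C(=N)Nc4cccc(C(F)(F)F)c4)nc(NC4CCCCC4)c32)cc1`: "not determined" (no result reported)

In a functional assay on PC-3 cells (Homo sapiens) for cytotoxicity, read by MTT assay, with a stated time of 72 h (on this read-out lower numbers stand for stronger inhibition and higher numbers for weaker inhibition), compound 2 gives 45400 nM, and compound 3 gives 32300 nM. Within the data shown here, the only measured step, a 1.4-fold lower number from compound 2 to compound 3 (0.15 log units; within the scatter), stays within the scatter, so compound 3 stands lowest of the two numbers without being separated from compound 2 by more than repeat measurements would give. Compound 1 carries the larger substituents on the shared core, but in this assay compound 1 has the entry "not determined" (no result reported) and cannot be used for comparison.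

Compound 4 `COc1ccc(Cn2ncc3cc(C(=N)Nc4ccc(N5CCN(C)CC5)cc4)ncc32)cc1` differs from compound 3 by 4-methoxyphenyl in place of hydrogen on a saturated chain carbon bound to an aromatic nitrogen. Among the measured compounds shown here, no measured pair tracks such a change: the single step from compound 2 to compound 3 concerns only the methyl on the aromatic nitrogen, not a 4-methoxyphenyl added on that methyl. With nothing pointing in either direction, the expected step of a 1.3-fold lower number from compound 3 to compound 4 (0.11 log units; within the scatter) is set to lie within the scatter. Compound 4 is therefore estimated at 25000 nM, with a range from 7000 nM to 90000 nM that reflects the missing precedent.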

Compound 4, half-maximal inhibitory concentration: 6100 nM
Compound 4: middle estimate off by 4.1-fold (0.61 log units), on the high side; the measured number lies below the stated range.
By their numbers in this assay, from the lowest: compound 4; then compounds 3 and 2 (each within the scatter of the next).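

In this assay, substitution on the aromatic nitrogen now separates compounds: replacing hydrogen with methyl stayed within the scatter (a 1.4-fold lower number from compound 2 to compound 3 (0.15 log units; within the scatter)), whereas extending methyl to 4-methoxybenzyl gives a 5.3-fold lower number from compound 3 to compound 4 (0.72 log units; beyond the scatter). The comparison with the unsubstituted nitrogen points the same way, with a 7.4-fold lower number from compound 2 to compound 4 (0.87 log units; beyond the scatter), so this site accepts the added 4-methoxyphenyl and the number falls beyond the scatter, although the change remains modest and compound 4 stands lowest of the three. The data shown give no basis for assigning a cause to this drop.

Going by these compounds, whether the step depends on the methoxy group or on the benzyl ring alone stays open; an unsubstituted benzyl group, or a benzyl group carrying a hydroxyl or a carboxylic acid in place of the methoxy, would separate these readings. Also open, on these data alone, is how the length of the link between the aromatic nitrogen and the ring bears on the number, as a phenethyl group would test, and whether the step carries over to the more heavily substituted core of compound 1.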